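A few compounds are considered here, and "the series" means these few. Any claim that something is new, unique, unknown or untested is made for them only; others in the source may bear on it.

Compound 1 `Cc1ccc(/C=C2\CN(Cc3cn(Cc4ccc(F)cc4)nn3)C/C(=C\c3ccc(C)cc3)C2=O)cc1` gives "not determined" (no result reported)
Compound 2 `COc1ccc(/C=C2\CN(C(=S)SCc3cn(Cc4cccc(Cl)c4)nn3)C/C(=C\c3ccc(OC)cc3)C2=O)cc1` gives > 100000 nM
Compound 3 `Cc1ccc(/C=C2\CN(Cc3cn(Cc4cccc(Cl)c4)nn3)C/C(=C\c3ccc(C)cc3)C2=O)cc1` gives 73500 nM

Going by the values given here, all three entries come from an ADME assay on HEK293 cells (Homo sapiens) for cytotoxicity, read by MTT assay, with a stated time of 24 h (on this read-out higher numbers stand for weaker inhibition and lower numbers for stronger inhibition), and only one is a true number. Compound 3 gives 73500 nM as that single number, so there is no other number to rank it against. Compound 2 shows > 100000 nM as a limit of the assay, not a number. Compound 4 `Cc1ccc(/C=C2\CN(Cc3cn(Cc4ccccc4F)nn3)C/C(=C\c3ccc(C)cc3)C2=O)cc1` differs from compound 3 in one place. The change is 2-fluorophenyl in place of 3-chlorophenyl on a saturated chain carbon bound to an aromatic nitrogen and reads 2-fluorophenyl in place of 3-chlorophenyl on a saturated chain carbon bound to an aromatic nitrogen. Among the compounds with values here, no measured pair shows this swap, so no shift beyond the usual scatter is expected, in either direction. The estimated step of a 1.1-fold lower number from compound 3 to compound 4 (0.02 log units; within the scatter) is accordingly small. The estimate for compound 4 is 70000 nM with an expected range from 30000 nM to 100000 nM.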

Compound 4, half-maximal inhibitory concentration: > 100000 nM
Compound 4 was reported as a limit (the forecaster's own chance of this, stated with the estimate: 30%); middle value at least 1.4-fold (0.15 log units) from the limit.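

In this assay, going by these compounds alone, the first step at this position, on a saturated chain carbon bound to an aromatic nitrogen, comes from 2-fluorophenyl in place of 3-chlorophenyl: an at least 1.3-fold higher number from compound 3 to compound 4 (0.13 log units; that floor lies within the scatter). Compound 4 gives > 100000 nM, which is a limit and not a number. The step is therefore only a floor, and the true size of the change stays unread: the limit of > 100000 nM in this assay, at which 2 of the 4 values shown sit.

The swap alters both the halogen and its place on the ring, and the compounds shown cannot separate the two. Also open, on these data alone, is how this position responds when that phenyl ring carries an amine or a carboxylic acid.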